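Swapping the aryl group on the ring amide nitrogen

The source may report more compounds than this note shows. Statements on the series, on what has been measured and on what is new or still open speak of the compounds shown alone.

Of the compounds shown here, two of a shared core have been tested in a functional assay on MCF7 cells (Homo sapiens) for antiproliferative activity, read by MTT assay, with a stated time of 72 h; a lower number here means a stronger inhibitor, a higher number a weaker inhibitor. Compound 1 `COc1ncc(-c2ccc3c(c2)N(c2ccc(C)cc2)C(=O)CO3)cc1NS(=O)(=O)c1ccc(F)cc1` gives 15400 nM in this assay, the lower of the two numbers; compound 2 `O=C1COc2ccc(-c3cccc(NS(=O)(=O)c4ccc(F)cc4)c3)cc2N1c1ccc(Cl)cc1` gives 39800 nM in this assay, a gap beyond the usual scatter. Compound 1 therefore stands at the stronger end of what is known here, though both numbers are weak.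

Compound 3 `COc1cccc(N2C(=O)COc3ccc(-c4cnc(OC)c(NS(=O)(=O)c5ccc(F)cc5)c4)cc32)c1` has not yet been measured. It differs from compound 1 in one place: 3-methoxyphenyl in place of 4-methylphenyl on an amide-type nitrogen in a ring. Going by the values given here, no pair of measured compounds shows what such a swap does, so the expectation rests on compound 1 alone. He expects the step from compound 1 to compound 3 to be small in either direction, most likely within the scatter, as a 1.0-fold lower number from compound 1 to compound 3 (0.01 log units; within the scatter) expresses. Compound 3 is accordingly estimated at 15000 nM in this assay, with a range from 5000 nM to 45000 nM.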

Compound 3, half-maximal inhibitory concentration: > 40000 nM
Compound 3: no number, only a limit; the forecaster's own chance of this, stated with the estimate: 15%; middle value at least 2.6-fold (0.42 log units) from the limit.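

The ring amide nitrogen is not indifferent to the aryl group it carries: 3-methoxyphenyl in place of 4-methylphenyl gives an at least 2.5-fold higher number from compound 1 to compound 3 (0.41 log units; beyond the scatter) in this assay, the first single change read at this position. Compound 3 gives > 40000 nM, and this value is a limit of the assay, not a number. The step therefore shows a weakening beyond the scatter, but its full size cannot be read, and the far end of the range in this series is set by a limit: the limit of > 40000 nM in this assay, at which 1 of the 3 values shown sits.

The compounds shown leave open whether the weakening belongs to the methoxy group itself or to where it sits on the phenyl ring, as this single swap changes both the substituent and its place. Also open, on these data alone, is how a 4-methoxyphenyl group, an unsubstituted phenyl or an ethyl chain on this same nitrogen would compare with the 4-methylphenyl group of compound 1 in this assay.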